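Three Analogues at the Assay Limit, a Fourth Awaited

The source may hold more compounds than are shown below. What is called first, only, known or untested is meant among the compounds shown, and "the series" means these compounds.

Compound 1, `N#CC1=C(N)Oc2c(c3nc4ccccc4nc3c3ccccc23)C12C(=O)N(Cc1cnnn1-c1ccccc1Cl)c1ccccc12`: > 50000 nM
Compound 2, `COc1ccccc1-n1nncc1CN1C(=O)C2(C(C#N)=C(N)Oc3c2c2nc4ccccc4nc2c2ccccc32)c2ccccc21`: > 50000 nM
Compound 3, `CCOc1ccc(-n2nncc2CN2C(=O)C3(C(C#N)=C(N)Oc4c3c3nc5ccccc5nc3c3ccccc43)c3ccccc32)cc1`: > 50000 nM

In an ADME assay on HUVEC cells (Homo sapiens) for antiproliferative activity, read by MTT assay, with a stated time of 48 h (a lower number here means a stronger inhibitor, a higher number a weaker inhibitor), compound 1 gives no number but a limit, > 50000 nM. Compound 2 likewise gives a limit in this assay, > 50000 nM. Compound 3 too gives a limit in this assay, > 50000 nM. Compound 1 therefore stands on a limit rather than a value, and the other two measured results are limits as well, all three sitting at the same point (the limit of > 50000 nM in this assay, at which 3 of the 3 values shown sit).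

The measured changes among these three all alter the aryl group on the aromatic nitrogen of the five-membered ring: a step that the two limits leave unreadable from compound 1 to compound 2; a step that the two limits leave unreadable from compound 1 to compound 3; a step that the two limits leave unreadable from compound 2 to compound 3. None of them can be read in size.

Compound 4 is `Cc1ccc(-n2nncc2CN2C(=O)C3(C(C#N)=C(N)Oc4c3c3nc5ccccc5nc3c3ccccc43)c3ccccc32)c(C)c1`. It differs from compound 1 thus: 2,4-dimethylphenyl in place of 2-chlorophenyl on an aromatic nitrogen. The three measured steps bear on this change, since each of them also exchanges the aryl group on that nitrogen, yet none of them showed a readable size. No step beyond the scatter is therefore expected in this assay, and compound 4 is expected to remain at the limit. Compound 4 is estimated at 60000 nM, within 20000 nM to 200000 nM. The expected step is a step that the limit leaves unreadable from compound 1 to compound 4.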

Compound 4, half-maximal inhibitory concentration: > 50000 nM
Compound 4 gave a limit, no number; the forecaster's own chance of this, stated with the estimate: 85%; the middle value is on the limit's open side.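

In this assay compound 4 gives a limit, > 50000 nM, and not a number. No step among compound 1, compound 2, compound 3 and compound 4 can be read, since all four stand at the same point: the limit of > 50000 nM in this assay, at which 4 of the 4 values shown sit.

The compounds shown leave open whether any other aryl group on that nitrogen would give a measurable value in this assay.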